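Removing a Methyl from the Aryl Ether of Compound 3

The compounds below may be only part of what the source reports. "The series", "measured", "known", "first", "only" and "open" are said of these compounds alone.

Compound 3 `CCOC(=O)c1c(-c2ccccc2OC)n(-c2ccc(C(=O)NNC(=O)CO[N+](=O)[O-])cc2)[nH]c1=O` gives the highest number of the three measured in a functional assay on aorta (Rattus norvegicus, strain Wistar) for inhibition (a lower number here means that less compound is needed, a higher number that more compound is needed for the effect), at 63.1 ug/mL. Compound 2 `CCOC(=O)c1c(-c2ccc([N+](=O)[O-])cc2)n(-c2ccc(C(=O)NNC(=O)CO[N+](=O)[O-])cc2)[nH]c1=O` gives 28.2 ug/mL, and compound 1 `O=C(CO[N+](=O)[O-])NNC(=O)c1ccc(-n2[nH]c(=O)cc2-c2ccccc2O)cc1` gives 17.8 ug/mL. Among the compounds with values here, the one measured step between close neighbours is a 2.2-fold higher number from compound 2 to compound 3 (0.35 log units; beyond the scatter). Compound 4 `CCOC(=O)c1c(-c2ccccc2O)n(-c2ccc(C(=O)NNC(=O)CO[N+](=O)[O-])cc2)[nH]c1=O` differs from compound 3 by hydrogen in place of methyl on an oxygen on an aromatic ring. Within the data shown here, no measured step covers this exact change, but compound 1 also carries a 2-hydroxyphenyl group and shows a lower number with 17.8 ug/mL, while compound 3 carries the methoxy and shows 63.1 ug/mL. A modest move toward a lower number is therefore expected, a 1.8-fold lower number from compound 3 to compound 4 (0.26 log units; within the scatter). Compound 4 is estimated in this assay at 35 ug/mL, within a range from 15 ug/mL to 85 ug/mL.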

Compound 4, half-maximal effective concentration: 70.8 ug/mL
Beside the measured number, compound 4's estimate is 2.0-fold (0.31 log units) below it, within the range that was stated.
By their numbers in this assay, from the lowest: compounds 1 and 2 (each within the scatter of the next); then compounds 3 and 4 (each within the scatter of the next).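

In this assay, hydrogen in place of methyl on this oxygen makes no clear difference, with a 1.1-fold higher number from compound 3 to compound 4 (0.05 log units; within the scatter) as the step. The 2-hydroxyphenyl group therefore does not by itself give a low number on this core: ethoxycarbonyl in place of hydrogen gives a 4.0-fold higher number from compound 1 to compound 4 (0.60 log units; beyond the scatter) and stands out more clearly, while 2-hydroxyphenyl in place of 4-nitrophenyl gives a 2.5-fold higher number from compound 2 to compound 4 (0.40 log units; beyond the scatter) as a further modest rise. Nothing at hand explains these numbers.

Still open, on these data alone, is how an ethyl on this oxygen, or an amine in place of the hydroxy, would read. As far as these compounds go, a carboxylic acid in place of the ethoxycarbonyl is equally open.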